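Swapping an aryl ether for a phenethyl chain

A few compounds are considered here, and "the series" means these few. Any claim that something is new, unique, unknown or untested is made for them only; others in the source may bear on it.

Compound 2 `COc1ccc(F)cc1CNCCCNc1ccnc2cc(Oc3ccc(C(C)(C)C)cc3)ccc12` gives 9.28 in a physicochemical assay for acid dissociation. It stands level with compound 1 `COc1ccc(F)cc1CNCCCNc1ccnc2cc(Oc3ccc(F)cc3)ccc12`, which gives 9.28, and with compound 3 `COc1cccc(CNCCCNc2ccnc3cc(Oc4ccc(C(C)(C)C)cc4)ccc23)c1O`, which gives 9.28. The step of no change at the digits printed from compound 1 to compound 2 (within the scatter) and the step of no change at the digits printed from compound 2 to compound 3 (within the scatter) both stayed within the scatter, although each altered a different part of the molecule. Compound 4 `COc1ccc(F)cc1CNCCCNc1ccnc2cc(CCc3ccccc3)ccc12` differs from compound 2 as follows: phenethyl in place of 4-(tert-butyl)phenoxy on an aromatic carbon. Among the compounds with values here, no measured step removes this whole group, yet the two steps that reshaped other parts of the same core left the value untouched, so the same outcome is expected here. The step expected is no change at the digits printed from compound 2 to compound 4 (within the scatter), none beyond the scatter. Compound 4 is estimated at 9.28, ranging from 8.95 to 9.6.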

Compound 4, acid dissociation constant: 9.47
Compound 4: the middle estimate sits 0.19 log units below what was measured; the measured number falls inside the stated range.
By their numbers in this assay, from the lowest: compounds 1, 2, 3 and 4 (each within the scatter of the next).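

In this assay, phenethyl in place of 4-(tert-butyl)phenoxy gives a number 0.19 log units higher from compound 2 to compound 4 (within the scatter), and phenethyl in place of 4-fluorophenoxy gives a number 0.19 log units higher from compound 1 to compound 4 (within the scatter). The earlier steps shown here kept the phenoxy group at this position, whereas here the whole group is exchanged, including its oxygen, and the reading still lies within the scatter. Nothing measured here offers an explanation for this result. As far as these compounds go, whether an amine or a carboxylic acid at this aromatic carbon would take the number beyond the scatter remains open.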